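Methoxy on the phenyl of compound 2

The compounds below may be only part of what the source reports. "The series", "measured", "known", "first", "only" and "open" are said of these compounds alone.

Of the compounds shown here, two have been measured so far in a physicochemical assay for lipophilicity (a lower number here means a more polar compound, a higher number a more lipophilic compound), as the only read-out. Compound 1 `CC1=C(C(=O)O)C(c2cccc(Cl)c2)C(C(=O)OCCC(c2ccccc2)c2ccccc2)=C(C(F)(F)F)N1` stands at 3.51 and compound 2 `COC(OC)C1=C(C(=O)OC/C=C/c2ccccc2)C(c2cccc(Cl)c2)C(C(=O)O)=C(C)N1` at 1.29 as the lower of the two numbers, with a gap beyond the scatter. Among the compounds with values here, these two differ in more than one place, so no single-change step is available as a guide.

Compound 3 `COc1ccccc1/C=C/COC(=O)C1=C(C(OC)OC)NC(C)=C(C(=O)O)C1c1cccc(Cl)c1` departs from compound 2 in one place: methoxy in place of hydrogen on an aromatic carbon (methoxy in place of hydrogen on an aromatic carbon, turning phenyl into 2-methoxyphenyl). In this assay no step beyond the scatter is expected, with any drift more likely upward. The estimated step is a number 0.11 log units higher from compound 2 to compound 3 (within the scatter) (small and upward). Compound 3 is estimated at 1.4 (expected range 1 to 1.8).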

Compound 3, distribution coefficient: 1.2
The estimate for compound 3 lay 0.20 log units above the measured number; low and high end bracket the measured number.
By their numbers in this assay, from the lowest: compounds 3 and 2 (each within the scatter of the next); then compound 1.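

The pair gives the series its first single-change step: in this assay, methoxy in place of hydrogen on an aromatic carbon, turning phenyl into 2-methoxyphenyl, reads as a number 0.09 log units lower from compound 2 to compound 3 (within the scatter). This assay therefore does not separate compound 2 from compound 3, and at this place, ortho to a large group, the added methoxy leaves the read-out within the scatter. Nothing measured here gives a reason for this result.

As far as these compounds go, whether an amine, a carboxylic acid or a longer chain at the same aromatic carbon would also stay within the scatter remains open. So does whether the methoxy step would carry over to compound 1, which differs from compound 2 in more than one place.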